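This account rests on a few compounds, and the source may have more. Where it says the series, first, only, none or still open, it means among the compounds named here.

Measured so far in a functional assay on the whole organism for inhibition, with Rattus norvegicus as the target, at a dose of 20 mg/kg by the oral route; on this read-out lower numbers stand for less inhibition and higher numbers for more inhibition at the one dose given (going by the name of the read-out):
compound 1, `NC(=O)/C=C1\CCc2c(Cl)cc(F)cc21`: 70%; 79% (2 entries)
compound 2, `CNC(=O)/C=C1\CCc2cc(Cl)cc(Cl)c21`: 22%
compound 3, `CNC(=O)/C=C1\CCc2cc(Cl)c(F)cc21`: 22%

Compound 2 sits at the low end of these numbers, level with compound 3, the two reading the same within the scatter. Compound 1, which differs from both at several places on the shared core, stands far higher in this assay, and its repeated entries agree closely, as the record the several entries of compound 1 in this assay, 70%; 79% (2 entries) shows. The unmeasured compound 4, `NC(=O)/C=C1\CCc2cc(Cl)cc(Cl)c21`, differs from compound 2 by a single change: hydrogen in place of methyl on an amide-type nitrogen. Among the compounds with values here, compound 1 likewise carries hydrogen rather than methyl at that nitrogen, though no measured step links it to compound 4. An upward step from compound 2 is expected in this assay, and compound 4 is estimated at 55%, within 25% to 85%, an expected step of a number 33 percentage points higher from compound 2 to compound 4 (beyond the scatter).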

Compound 4, a percentage reported as inhibition, in the whole organism at one dose (the size of the read-out at that dose, not a potency): 79%
Compound 4: the middle estimate sits 24 percentage points below what was measured; the range from low to high includes it.
By their numbers in this assay, from the lowest: compounds 2 and 3 (each within the scatter of the next); then compound 4.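

In this assay, hydrogen in place of methyl on the amide-type nitrogen, with nothing else changed, gives a number 57 percentage points higher from compound 2 to compound 4 (beyond the scatter). Within the data shown here, this is the first direct sign that this nitrogen matters on the shared core, since no earlier pair differed in only one place. The step is also much wider than the gap between repeated entries for one compound: the several entries of compound 1 in this assay, 70%; 79% (2 entries)

As far as these compounds go, whether the same change would raise the value of compound 3 stays open. So does the effect of an ethyl group or a longer chain on that nitrogen.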